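A few compounds are considered here, and "the series" means these few. Any claim that something is new, unique, unknown or untested is made for them only; others in the source may bear on it.

Of the compounds shown here, three of a shared core have been measured in an assay on isolated protein for inhibition of DNA topoisomerase 1 (Homo sapiens), with a stated time of 30 min, tested at 20 uM; on this read-out lower numbers stand for a weaker effect and higher numbers for a stronger effect at the one concentration tested. Compound 1 `Cc1ccc2nc(-c3ccccc3N(C)C)[nH]c(=O)c2c1` gives 21.1%, compound 2 `Cc1ccc2c(=O)[nH]c(-c3ccccc3C)nc2c1` gives 39.2%, and compound 3 `CCN(CC)c1ccc2nc(-c3ccccc3OC(F)(F)F)[nH]c(=O)c2c1` gives 0%. On these numbers compound 2 stands highest of the three: its nearest neighbour is compound 1, whose number lies lower by a difference beyond the scatter, and its furthest is compound 3, whose number lies lower by a difference that is also beyond the scatter.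

Compound 4 `Cc1ccc2c(=O)[nH]c(-c3ccccc3F)nc2c1` has not yet been measured in this assay. Compared with compound 2, the change is fluoro in place of methyl on an aromatic carbon. For the measured compounds named here, no other pair among the measured compounds differs only in this one place, so there is no measured step to lean on. Given that the exchange keeps the same count of heavy atoms, donors and acceptors, the step from compound 2 to compound 4 is expected to be modest and toward a weaker effect, a number 11.2 percentage points lower from compound 2 to compound 4 (beyond the scatter), a change that could still fall within the usual scatter. On that basis compound 4 is expected to give about 28% in this assay, with a range from 10% to 48%.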

Compound 4, a percentage reported as inhibition, at one concentration (the size of the read-out at that concentration, not a potency): 0%
For compound 4 the middle estimate is 28 percentage points above the measured one; measured number below the stated range.
By their numbers in this assay, from the lowest: compounds 3 and 4 (each within the scatter of the next); then compound 1; then compound 2.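

For the compounds shown here, until now no two measured compounds differed in only one place, so nothing showed how the aromatic carbon ortho to a large group responds to a single exchange. In this assay, fluoro in place of methyl at this carbon gives a number 39.2 percentage points lower from compound 2 to compound 4 (beyond the scatter), so this position proves sensitive to the identity of its substituent, and the step is large. The exchange leaves the count of heavy atoms, donors and acceptors unchanged, so those counts do not account for the difference, and no measurement at hand offers an explanation for it.

The compounds shown leave open whether methyl is unusual at this place or whether fluoro alone loses the effect, and a chloro group, an ethyl chain, a methoxy group or a bare hydrogen on the same carbon would separate those two readings. They also leave open whether the exchange of methyl for fluoro has a step of similar size on a core that carries something other than the methyl of compound 2, such as a diethylamino group.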